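An Oxan-4-yl Ring Replaces 3-Fluoropropyl on an Aromatic Nitrogen

A few compounds are considered here, and "the series" means these few. Any claim that something is new, unique, unknown or untested is made for them only; others in the source may bear on it.

Compound 1 `CN1C(=S)[C@@H](NC(=O)c2nc(Cc3ccccc3)n(CCCF)n2)COc2ccccc21`: in a toxicity assay on HT-29 cells (Homo sapiens) for cytotoxicity (on this read-out lower numbers stand for higher toxicity in this test and higher numbers for lower toxicity in this test), compound 1 gives > 100000 nM, which is a limit of the assay.
Compound 2 `CN1C(=S)[C@@H](NC(=O)c2nc(Cc3ccccc3)n(CCC(F)(F)F)n2)COc2ccccc21`: in this assay compound 2 gives > 100000 nM, which is likewise a limit.

Among the compounds with values here, compound 1 stands at the top of the measured window: the only number recorded for it is a limit, and the one further value on record is a limit as well, so neither compound is placed on an actual scale. Within the data shown here, the single measured step, a step that the two limits leave unreadable from compound 1 to compound 2, cannot be read, since (the limit of > 100000 nM in this assay, at which 2 of the 2 values shown sit).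

Compound 3 `CN1C(=S)[C@@H](NC(=O)c2nc(Cc3ccccc3)n(C3CCOCC3)n2)COc2ccccc21` differs from compound 1 in one place: oxan-4-yl in place of 3-fluoropropyl on an aromatic nitrogen. Among the measured compounds shown here, the measured step concerns a change on the same aromatic nitrogen, but it gives no readable size, and no other pair bears on the oxan-4-yl substitution. For the measured compounds named here, the only guidance is that both measured compounds sit at the limit.

Compound 3 is therefore expected to stay near that limit, with a step from compound 1 of about a number no higher from compound 1 to compound 3 (the limit leaves the size open), and an estimated value of 100000 nM, between 30000 nM and 300000 nM.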

Compound 3, half-maximal cytotoxic concentration: > 100000 nM
Compound 3: no number, only a limit; the forecaster's own chance of this, stated with the estimate: 80%; the middle value sits exactly at the limit.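

No step can be read from compound 1 or compound 2 to compound 3 in this assay, because all three compounds stand at the same limit: the limit of > 100000 nM in this assay, at which 3 of the 3 values shown sit.

The compounds shown leave open whether the 3-fluoropropyl, 3,3,3-trifluoropropyl and oxan-4-yl groups on the aromatic nitrogen differ at all in this read-out, and at what concentration any of the three compounds would become toxic to these cells.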